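The source may hold more compounds than are shown below. What is called first, only, known or untested is meant among the compounds shown, and "the series" means these compounds.

Compound 3 `O=C(CSc1nnc(-c2ccncc2)o1)N/N=C/c1cc(Cl)ccc1O` gives the lowest number of the three measured in a functional assay on BGC-823 cells (Homo sapiens) for cytotoxicity, read by MTT assay, with a stated time of 48 h (a higher number here means a weaker inhibitor, a lower number a stronger inhibitor), at 5470 nM; compound 1 `COc1ccc(/C=N/NC(=O)CSc2nnc(-c3ccncc3)o2)cc1` gives 19800 nM and compound 2 `O=C(CSc1nnc(-c2ccncc2)o1)N/N=C/c1ccccc1[N+](=O)[O-]` gives 41600 nM. Both neighbours differ from compound 3 only in the aryl group on the carbon with a double bond to nitrogen: a 3.6-fold lower number from compound 1 to compound 3 (0.56 log units; beyond the scatter), and a 7.6-fold lower number from compound 2 to compound 3 (0.88 log units; beyond the scatter). Compound 4 `COc1cc(/C=N/NC(=O)CSc2nnc(-c3ccncc3)o2)ccc1O` alters the same carbon: 4-hydroxy-3-methoxyphenyl in place of 5-chloro-2-hydroxyphenyl on a carbon with a double bond to nitrogen. The entering group shares a methoxy with the 4-methoxyphenyl of compound 1, whose 19800 nM sits above that of compound 3, so a number part of the way back toward compound 1 is expected, with the two measured swaps disagreeing enough in size that the bearing is loose. The expected step is a 2.2-fold higher number from compound 3 to compound 4 (0.34 log units; beyond the scatter). For compound 4 the estimate in this assay is 12000 nM, with a range from 4000 nM to 40000 nM.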

Compound 4, half-maximal inhibitory concentration: 4320 nM
Estimate against measurement, compound 4: 2.8-fold (0.44 log units) above; measured number inside the range.
By their numbers in this assay, from the lowest: compounds 4 and 3 (each within the scatter of the next); then compound 1; then compound 2.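

In this assay, the aryl group on the carbon with a double bond to nitrogen can change from 5-chloro-2-hydroxyphenyl to 4-hydroxy-3-methoxyphenyl with a 1.3-fold lower number from compound 3 to compound 4 (0.10 log units; within the scatter), so chlorine is not needed for a number at this level. The two hydroxy-bearing compounds both stand clear of the others, with a 4.6-fold lower number from compound 1 to compound 4 (0.66 log units; beyond the scatter) and a 9.6-fold lower number from compound 2 to compound 4 (0.98 log units; beyond the scatter), and none of the four compounds goes against this link. No measurement on hand explains the link.

Among these compounds, no pair here differs by the hydroxy alone, so its own share stays open. Also open, going by these compounds, is how an aryl group bearing an amine or a carboxylic acid would read.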